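Amide aryl variation on the shared core: next step

The compounds below may be only part of what the source reports. "The series", "measured", "known", "first", "only" and "open" are said of these compounds alone.

Compound 2 `CN1[C@@H]2c3[nH]c4ccccc4c3C[C@H]1[C@H](C#N)N1[C@@H](CNC(=O)c3ccc4ccccc4c3)c3[nH]c4ccccc4c3C[C@@H]21` carries a naphthalen-2-yl group on the amide carbonyl and gives 4940 nM in a functional assay on HT-29 cells (Homo sapiens) for cytotoxicity, read by MTT assay, with a stated time of 72 h (a lower number here means a stronger inhibitor, a higher number a weaker inhibitor), the higher of the two numbers recorded so far. Going by the values given here, its nearest neighbour is compound 1 `CN1[C@@H]2c3[nH]c4ccccc4c3C[C@H]1[C@H](C#N)N1[C@@H](CNC(=O)c3ccc(Cl)cc3)c3[nH]c4ccccc4c3C[C@@H]21`, which in this assay gives 130 nM; the only recorded step, a 38-fold higher number from compound 1 to compound 2 (1.58 log units; beyond the scatter), shows how much the exchange of the aryl group on this carbonyl can move the number. Compound 3 `CN1[C@@H]2c3[nH]c4ccccc4c3C[C@H]1[C@H](C#N)N1[C@@H](CNC(=O)/C=C/c3cccc(C(F)(F)F)c3)c3[nH]c4ccccc4c3C[C@@H]21` differs from compound 2 in the same place: 2-(3-(trifluoromethyl)phenyl)ethenyl in place of naphthalen-2-yl on a carbonyl carbon. That step is the only one that bears on the change, and it points only to the size an aryl swap at this carbonyl can reach, not to its direction here. A modest shift towards a lower number is expected, since compound 1 shows the carbonyl substituent can be far less harmful than naphthalen-2-yl. The estimated step is a 3.3-fold lower number from compound 2 to compound 3 (0.52 log units; beyond the scatter). Compound 3 is expected to give about 1500 nM in this assay, within 300 nM to 8000 nM.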

Compound 3, half-maximal inhibitory concentration: 5060 nM
Compound 3: middle estimate off by 3.4-fold (0.53 log units), on the low side; measured number inside the range.
By their numbers in this assay, from the lowest: compound 1; then compounds 2 and 3 (each within the scatter of the next).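

In this assay, the step of a 1.0-fold higher number from compound 2 to compound 3 (0.01 log units; within the scatter) shows that 2-(3-(trifluoromethyl)phenyl)ethenyl and naphthalen-2-yl cannot be told apart on this carbonyl carbon, even though one has a single aromatic ring and a double bond outside aromatic rings and the other has two aromatic rings. The step of a 39-fold higher number from compound 1 to compound 3 (1.59 log units; beyond the scatter) is about as large as a 38-fold higher number from compound 1 to compound 2 (1.58 log units; beyond the scatter) and shows that, among these three compounds, the large loss is not confined to naphthalen-2-yl: both replacements of 4-chlorophenyl sit well apart from compound 1. No measured data explain this shared loss.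

The compounds shown leave open whether the low number of compound 1 depends on its chlorine, which an unsubstituted phenyl group on the same carbonyl carbon could test. A 2-(4-chlorophenyl)ethenyl group could test whether the ethenyl link alone is tolerated.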